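Cyano in place of bromo on the fused ring system

This account rests on a few compounds, and the source may have more. Where it says the series, first, only, none or still open, it means among the compounds named here.

In an ADME assay on microsomes from liver (Mus musculus) for metabolic stability (a higher number here means faster removal of the compound, a lower number slower removal), the three measured compounds gave:
Compound 1 `COc1cc([C@](O)(CCN(C)C)[C@@H](c2cc3cc(Br)ccc3nc2OC)c2cccc(OC)c2F)cc(OC(C)C)n1`: 6 uL/min
Compound 2 `COc1cc([C@](O)(CCN(C)C)[C@@H](c2cc3cc(Br)ccc3nc2OC)c2cccc(OC)c2F)cc(OC(F)F)n1`: 6.4 uL/min
Compound 3 `COc1cc([C@](O)(CCN(C)C)[C@@H](c2cc3cc(Br)ccc3nc2OC)c2cccc(OC)c2F)cc(SC)n1`: 20 uL/min

Compound 3 stands highest of the three; the steps of a 3.3-fold higher number from compound 1 to compound 3 (0.52 log units; beyond the scatter) and a 3.1-fold higher number from compound 2 to compound 3 (0.49 log units; beyond the scatter) both lie beyond the scatter, while a 1.1-fold higher number from compound 1 to compound 2 (0.03 log units; within the scatter) does not. Compound 4 `COc1cc([C@](O)(CCN(C)C)[C@@H](c2cc3cc(C#N)ccc3nc2OC)c2cccc(OC)c2F)cc(SC)n1` differs from compound 3 in one place: cyano in place of bromo on an aromatic carbon. Among the measured compounds shown here, none of the measured steps bears on this change, since each of them concerns the isopropoxy, difluoromethoxy or methylsulfanyl group, and the bromo is shared by all three measured compounds. With nothing to lean on, the expected step in this assay is none beyond the scatter, that is no change at the digits printed from compound 3 to compound 4 (within the scatter). For compound 4 the estimate is therefore 20 uL/min, with a range from 8 uL/min to 50 uL/min.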

Compound 4, intrinsic clearance in a liver preparation (reported as CLH), per the amount of preparation that the assay uses: 36 uL/min
The estimate for compound 4 lay 1.8-fold (0.26 log units) below the measured number, within the range that was stated.
By their numbers in this assay, from the lowest: compounds 1 and 2 (each within the scatter of the next); then compounds 3 and 4 (each within the scatter of the next).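

Among the compounds shown here, the swap of bromo for cyano on the six-membered carbon ring of the fused system is the first change at this position, and in this assay it gives a 1.8-fold higher number from compound 3 to compound 4 (0.26 log units; within the scatter). With methylsulfanyl on the other ring, this position therefore tolerates either group without a change that stands clear of the scatter. Nothing measured here offers an explanation for this result.

On these data alone, whether the same holds alongside isopropoxy or difluoromethoxy remains open. As far as these compounds go, how an amine, a carboxylic acid or a longer chain would fare at this position is also open.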